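Replacing 3-methylthiophen-2-yl with 4-chlorophenyl in compound 1

The source may report more compounds than this note shows. Statements on the series, on what has been measured and on what is new or still open speak of the compounds shown alone.

Compound 1 `Cc1ccc(S(=O)(=O)/C(=C/c2sccc2C)C(=O)c2ccc(Cl)cc2)cc1` gives 10000 nM
Compound 2 `O=C(/C(=C\c1c(O)cc(O)cc1O)S(=O)(=O)c1ccccc1Br)c1ccc(Cl)cc1` gives 50000 nM
Compound 3 `Cc1ccc(S(=O)(=O)/C(=C/c2sccc2C)C(=O)c2ccc(Br)cc2)cc1` gives 25000 nM

All three values come from a functional assay on DU-145 cells (Homo sapiens) for inhibition, read by trypan blue exclusion, with a stated time of 96 h (a lower number here means a stronger inhibitor of growth, a higher number a weaker inhibitor of growth), and compound 1 has the lowest number of the three. Compound 4 `Cc1ccc(S(=O)(=O)/C(=C/c2ccc(Cl)cc2)C(=O)c2ccc(Cl)cc2)cc1` has not yet been measured and differs from compound 1 by one exchange (4-chlorophenyl in place of 3-methylthiophen-2-yl on a double-bonded chain carbon bound to a double-bonded chain carbon) with 4-chlorophenyl in place of 3-methylthiophen-2-yl on a double-bonded chain carbon bound to a double-bonded chain carbon.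

Going by the values given here, no measured pair covers this exchange. Among the compounds with values here, the only single-place step available is a 2.5-fold higher number from compound 1 to compound 3 (0.40 log units; beyond the scatter) for bromo in place of chloro on an aromatic carbon. That step is modest, though beyond the scatter, and it concerns a different group, so it gives only a rough idea of how far one change can move the number on this core. It says nothing firm about direction. Within the data shown here, compound 1 already has the lowest value so far (10000 nM) and this leaves a slight lean towards a higher number. The expected step is a 1.2-fold higher number from compound 1 to compound 4 (0.08 log units; within the scatter) in this assay and no change beyond the scatter is expected. For compound 4 the estimated value is 12000 nM (expected range 3000 nM to 45000 nM).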

Compound 4, concentration for 50% growth inhibition: 1000 nM
Compound 4: the middle estimate sits 12-fold (1.08 log units) above what was measured; measured number outside the range, below it.
By their numbers in this assay, from the lowest: compound 4; then compound 1; then compounds 3 and 2 (each within the scatter of the next).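

In this assay, the group at this place, on a double-bonded chain carbon bound to a double-bonded chain carbon, has a large influence on growth inhibition: putting 4-chlorophenyl in place of 3-methylthiophen-2-yl gives a 10-fold lower number from compound 1 to compound 4 (1.00 log units; beyond the scatter). Going by these compounds alone, the only earlier single-place step, bromo in place of chloro on an aromatic carbon, gave a 2.5-fold higher number from compound 1 to compound 3 (0.40 log units; beyond the scatter), so the new result shows that a single exchange on this core can also lower the number, and by a wider margin. Ring size, the sulfur, the methyl and the chlorine all change together in this exchange, and nothing available here shows which of them accounts for the drop.

From the compounds shown here alone, it remains open whether a plain phenyl ring at this place would keep the low number, or how a ring carrying an amine or a carboxylic acid there would compare. Also open, going by these compounds, is whether bromo in place of chloro on an aromatic carbon would raise the number on compound 4 as it did on compound 1.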